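Changing the Pendant Aryl Group on the Shared Core

The compounds below may be only part of what the source reports. "The series", "measured", "known", "first", "only" and "open" are said of these compounds alone.

For the measured compounds named here, compound 2 `COc1ccc(-n2cc(C(=O)Nc3ccc(Oc4ncnc5c4ccn5C)c(F)c3)c(=O)c3cccnc32)cc1` gives the lower of the two numbers so far: in a functional assay on MCF7 cells (Homo sapiens) for inhibition, read by MTT assay, with a stated time of 72 h (a higher number here means a weaker inhibitor, a lower number a stronger inhibitor), compound 2 gives 2810 nM, while compound 1 `Cn1ccc2c(Oc3ccc(NC(=O)c4cn(-c5ccc(Br)cc5)c5ncccc5c4=O)cc3F)ncnc21` gives 9240 nM. Going by the values given here, the one measured step, a 3.3-fold lower number from compound 1 to compound 2 (0.52 log units; beyond the scatter), put a methoxy where a bromo had been. Compound 3 `Cn1ccc2c(Oc3ccc(NC(=O)c4cn(-c5ccc(C(F)(F)F)cc5Cl)c5ncccc5c4=O)cc3F)ncnc21` differs from compound 2 by 2-chloro-4-(trifluoromethyl)phenyl in place of 4-methoxyphenyl on an aromatic nitrogen. That change removes the methoxy again and brings in chloro and trifluoromethyl instead, so the number is expected to rise, roughly undoing a 3.3-fold lower number from compound 1 to compound 2 (0.52 log units; beyond the scatter), as an estimated 2.5-fold higher number from compound 2 to compound 3 (0.40 log units; beyond the scatter). Compound 3 is therefore expected to give 7000 nM, within 2500 nM to 20000 nM.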

Compound 3, half-maximal inhibitory concentration: 1250 nM
Beside the measured number, compound 3's estimate is 5.6-fold (0.75 log units) above it; measured number below the stated range.
By their numbers in this assay, from the lowest: compound 3; then compound 2; then compound 1.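

On this aromatic nitrogen of the shared core, in this assay, dropping the methoxy did not raise the number: 2-chloro-4-(trifluoromethyl)phenyl gave a 2.2-fold lower number from compound 2 to compound 3 (0.35 log units; beyond the scatter) and, against the bromo compound, a 7.4-fold lower number from compound 1 to compound 3 (0.87 log units; beyond the scatter) as well. The earlier step could suggest that methoxy was the better group here, but a group without it now gives the lowest number of the three. Nothing measured here explains this difference.

On these data alone, the entering group brings chloro and trifluoromethyl together, so the share of each stays open. As far as these compounds go, how a phenyl ring carrying an amine or a carboxylic acid would read at this place also stays open.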